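A few compounds are considered here, and "the series" means these few. Any claim that something is new, unique, unknown or untested is made for them only; others in the source may bear on it.

Working notes on the series. Of the compounds shown here, three have been measured in a functional assay on the whole organism for inhibition, with Mus musculus as the target, at a dose of 10 mg/kg by the oral route; a lower number here means less inhibition, a higher number more inhibition at the dose given (going by the name of the read-out). Compound 1, `CSc1ccc2c(c1)c(O)c(C(=S)N(C)c1ccccc1)c(=O)n2C`, gives 32% in this assay. Compound 2, `Cc1ccc2c(c1)C(=O)/C(=C(\S)N(C)c1ccccc1)C(=O)N2C`, gives 20% in this assay. Compound 3, `COc1ccc(N(C)/C(S)=C2/C(=O)c3cc(Cl)ccc3N(C)C2=O)cc1`, gives 45% in this assay. Compound 3 therefore stands highest of the three numbers: its nearest neighbour is compound 1, a number beyond the scatter lower, and the furthest is compound 2, lower still and also beyond the scatter. Among these three, compound 3 has the highest number in this assay. Among the compounds with values here, no pair of measured compounds differs in a single place, so no measured step is available to calibrate any one change.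

Compound 4, `CN1C(=O)/C(=C(/S)N(C)c2cccc(Cl)c2)C(=O)c2cc(Cl)ccc21`, has not yet been measured in this assay. It differs from compound 3 by 3-chlorophenyl in place of 4-methoxyphenyl on an amine nitrogen. No measured pair shows what such a swap on that nitrogen does, so the direction of the step from compound 3 to compound 4 cannot be read from the numbers shown. The expectation is a step of moderate size in either direction, a number 5 percentage points lower from compound 3 to compound 4 (within the scatter), with the value of compound 3 as the anchor. Compound 4 is estimated at 40% in this assay, with a range from 20% to 60%.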

Compound 4, a percentage reported as inhibition, in the whole organism at one dose (the size of the read-out at that dose, not a potency): 63%
Compound 4: middle estimate off by 23 percentage points, on the low side; the whole stated range lies below it.
By their numbers in this assay, from the lowest: compound 2; then compound 1; then compound 3; then compound 4.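

Within the data shown here, the exchange of 4-methoxyphenyl for 3-chlorophenyl on the amine nitrogen provides the first single-place step: in this assay the step is a number 18 percentage points higher from compound 3 to compound 4 (beyond the scatter) and so shows that one change at this position can move the read-out beyond the scatter. By the counts, the exchange leaves one heavy atom fewer and one hydrogen-bond acceptor fewer, with donors and net charge unchanged, and here it goes upward at the dose given rather than leaving the number in place. Nothing available bears on why the number rises.

This single step cannot separate the loss of the methoxy group from the arrival of the chlorine, nor either of these from the different location of the substituent on the aromatic ring. Also open, on these data alone, are how a carboxylic acid, an amine or a longer chain in place of 3-chlorophenyl on that nitrogen would read out, and whether the same exchange gives a step of this direction on the cores of compound 1 and compound 2.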